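This account rests on a few compounds, and the source may have more. Where it says the series, first, only, none or still open, it means among the compounds named here.

Of the compounds shown here, three that share one core have been measured in a functional assay on MCF7 cells (Homo sapiens) for inhibition, read by sulforhodamine B assay, with a stated time of 48 h, tested at 50 uM; a lower number here means less inhibition of growth, a higher number more inhibition of growth at the concentration tested. Compound 1 `COc1ccc([C@@H]2C/C(=N/OCc3cn(-c4ccc(Cl)cc4C)nn3)c3cc(CC=C(C)C)c(OC)cc3O2)cc1` gives 37%, compound 3 `C#CCO/N=C1/C[C@@H](c2ccc(OC)cc2)Oc2cc(OC)c(CC=C(C)C)cc21` gives 61%, and compound 2 `COc1cc2c(cc1CC=C(C)C)C(=O)C[C@@H](c1ccc(Oc3ccccc3)cc1)O2` gives 69%, the highest of the three numbers; its gap to compound 3 lies within the usual scatter, and only its gap to compound 1 lies beyond it. Compound 4 `CCCOc1ccc([C@@H]2CC(=O)c3cc(CC=C(C)C)c(OC)cc3O2)cc1` has not yet been measured. It differs from compound 2 in one place: propyl in place of phenyl on an oxygen on an aromatic ring. Going by the values given here, no measured pair shows this change, so nothing here tells how large its effect is. A modest fall in this assay is expected, as the step of a number 14 percentage points lower from compound 2 to compound 4 (beyond the scatter). Compound 4 is expected to give about 55%, somewhere between 35% and 75%.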

Compound 4, percent growth inhibition at one concentration: 60%
For compound 4 the middle estimate is 5 percentage points below the measured one; the range from low to high includes it.
By their numbers in this assay, from the lowest: compound 1; then compounds 4, 3 and 2 (each within the scatter of the next).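

In this assay, going by these compounds alone, putting propyl in place of phenyl on this oxygen brings a number 9 percentage points lower from compound 2 to compound 4 (within the scatter) and so gives the first direct reading of this change. For this pair, growth inhibition at the tested concentration does not depend on keeping the aromatic ring at this position, since the open chain cannot be told apart from it. Nothing available gives a reason for this result.

Still open, on these data alone, is whether a longer chain, such as hexyl, would fit as well as propyl. An amine or a carboxylic acid at the end of the chain also remains to be explored.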